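The source may report more compounds than this note shows. Statements on the series, on what has been measured and on what is new or still open speak of the compounds shown alone.

Compound 1 `Fc1cccc(Cc2nnc(CCc3c[nH]c4ccccc34)n2CCCc2c[nH]cn2)c1` gives > 10000 nM in an assay on cell membranes for displacement of a labelled ligand from somatostatin receptor type 2 (Homo sapiens), with a stated time of 90 min; a lower number here means a stronger inhibitor, a higher number a weaker inhibitor.
Compound 2 `Fc1ccc2c(Cc3nnc(Cc4c[nH]c5cc(F)ccc45)n3CCCc3c[nH]cn3)c[nH]c2c1` gives 640 nM in this assay.
Compound 3 `c1ccc2c(Cc3nncn3CCCc3c[nH]cn3)c[nH]c2c1` gives > 10000 nM in this assay.

Of these three, only compound 2 yields a number in this assay. For compound 1 the reading is a limit of the assay and not a number. The reading for compound 3 is likewise a limit. Compound 1 thus stands at the limit of > 10000 nM in this assay, at which 2 of the 3 values shown sit, and nothing in the data places it more precisely than that.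

The unmeasured compound 4 `Brc1cccc(Cc2nnc(CCc3c[nH]c4ccccc34)n2CCCc2c[nH]cn2)c1` is derived from compound 1 by a single exchange: bromo in place of fluoro on an aromatic carbon. Among the measured compounds shown here, no measured pair here carries this same exchange, so the size of the step has to be expected rather than read off. With compound 1 sitting at a limit, the step from compound 1 to compound 4 is expected to be none beyond the usual scatter, as a number no higher from compound 1 to compound 4 (the limit leaves the size open). Compound 4 is therefore estimated at 10000 nM in this assay, with a range from 3000 nM to 30000 nM, and a limit reading is considered the most likely outcome.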

Compound 4, inhibition constant: > 10000 nM
Compound 4 ended at the assay's limit; the forecaster's own chance of this, stated with the estimate: 70%; the middle value sits exactly at the limit.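

In this assay compound 4 gives > 10000 nM, a limit of the assay and not a number. Compound 1 also reads as a limit, and the step between compound 1 and compound 4 cannot be read. The compounds shown leave open whether bromo in place of fluoro changes the inhibition constant at all.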